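The source may report more compounds than this note shows. Statements on the series, on what has been measured and on what is new or still open speak of the compounds shown alone.

Measured in an ADME assay for permeability, using PAMPA, at pH 7.4; on this read-out higher numbers stand for higher permeability and lower numbers for lower permeability:
Compound 1 `O=C(Nc1cccc(-c2nc3ccccc3s2)c1)c1cc([N+](=O)[O-])c(O)cc1Cl`: 307 10^-6 cm/s
Compound 2 `COC(=O)C1CCN(c2cc(Cl)c(C(=O)Nc3cc(-c4nc5ccccc5s4)ccc3C)cc2[N+](=O)[O-])CC1`: 24 10^-6 cm/s
Compound 3 `O=C(Nc1nc2ccc(F)cc2s1)c1cc([N+](=O)[O-])ccc1Cl`: 10 10^-6 cm/s

Compound 1 stands highest of these three, and both others lie lower by more than the usual scatter. Compound 4 `COc1cc(Cl)c(C(=O)Nc2cccc(-c3nc4ccccc4s3)c2)cc1[N+](=O)[O-]`, not yet measured, differs from compound 1 by one change: methyl in place of hydrogen on an oxygen on an aromatic ring, or hydroxy to methoxy. Among the compounds with values here, no measured pair shows this change, so the expectation is loose. With compound 1 at 307 10^-6 cm/s, there is much more room below than above, so a moderate downward step in this assay is expected. The estimated step is a 2.6-fold lower number from compound 1 to compound 4 (0.41 log units; beyond the scatter). For compound 4 the estimate is 120 10^-6 cm/s, with an expected range of 30 10^-6 cm/s to 400 10^-6 cm/s.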

Compound 4, apparent permeability in the ADME assay: 12 10^-6 cm/s
The estimate for compound 4 lay 10-fold (1.00 log units) above the measured number; the whole stated range lies above it.
By their numbers in the ADME assay, from the lowest: compounds 3, 4 and 2 (each within the scatter of the next, the first and the last beyond it); then compound 1.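

Within the data shown here, this is the first pair here that differs in one place, and hydroxy to methoxy on this aromatic ring gives, in the ADME assay, a 26-fold lower number from compound 1 to compound 4 (1.41 log units; beyond the scatter). In a physicochemical assay for solubility, read by spectrophotometry, in phosphate buffer, measured as kinetic solubility, with a stated time of 18 h, at pH 7.4 (a lower number here means a less soluble compound, a higher number a more soluble compound), compound 1 gives 2200 nM and compound 4 gives 10 nM. In the physicochemical assay, the same change gives a 220-fold lower number from compound 1 to compound 4 (2.34 log units; beyond the scatter). Little of compound 4 staying in solution may therefore contribute to its low permeability reading: the measured solubility of compound 1, 2200 nM, and of compound 4, 10 nM, a 220-fold lower number (2.34 log units; beyond the scatter). The compounds shown carry only hydrogen or methyl on this oxygen, so how a longer chain, or a chain ending in an amine, would read in either assay stays open.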